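A few compounds are considered here, and "the series" means these few. Any claim that something is new, unique, unknown or untested is made for them only; others in the source may bear on it.

Working notes on the series in a functional assay on OVCAR-8 cells (Homo sapiens) for antiproliferative activity; a lower number here means a stronger inhibitor, a higher number a weaker inhibitor. Compound 1 `Cn1ncc(Cl)c1-c1cc(C(=O)N[C@@H]2CN[C@H](CC(O)CO)C[C@H]2c2ccc(Cl)c(Cl)c2)oc1Cl` gives 1610 nM, compound 2 `Cn1ncc(Cl)c1-c1cc(C(=O)N[C@@H]2CN[C@H](CCN3CCCCC3)C[C@H]2c2ccc(Cl)c(Cl)c2)oc1Cl` gives 1660 nM, and compound 3 `CCC[C@@H]1C[C@@H](c2ccc(Cl)c(Cl)c2)[C@H](NC(=O)c2cc(-c3c(Cl)cnn3C)c(Cl)o2)CN1` gives 1620 nM. Compound 3 stands level with the other two, and nothing separates it from either. The step linking it to the piperidine member is a 1.0-fold lower number from compound 2 to compound 3 (0.01 log units; within the scatter).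

Compound 4 `Cn1ncc(Cl)c1-c1cc(C(=O)N[C@@H]2CN[C@H](CC(=O)NC3CC3)C[C@H]2c2ccc(Cl)c(Cl)c2)oc1Cl` carries cyclopropylcarbamoyl in place of ethyl on a saturated chain carbon bound to a saturated ring carbon.

Two further measured steps bear on this change, as both alter the group at the same chain. One is a 1.0-fold higher number from compound 1 to compound 2 (0.01 log units; within the scatter), for (piperidin-1-yl)methyl in place of 1,2-dihydroxyethyl. The other is a 1.0-fold higher number from compound 1 to compound 3 (0.00 log units; within the scatter), for ethyl in place of 1,2-dihydroxyethyl. Neither leaves the scatter, and on these steps no shift beyond the scatter is expected in this assay, in either direction. For the measured compounds named here, no measured compound carries a cyclopropylcarbamoyl group, and three compounds are a thin base, so the range is kept wide.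

The estimated step is a 1.0-fold lower number from compound 3 to compound 4 (0.01 log units; within the scatter). For compound 4 the expected value is 1600 nM, with an estimated range of 800 nM to 3200 nM.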

Compound 4, half-maximal inhibitory concentration: 580 nM
The estimate for compound 4 lay 2.8-fold (0.44 log units) above the measured number, and the stated range ends above it.
By their numbers in this assay, from the lowest: compound 4; then compounds 1, 3 and 2 (each within the scatter of the next).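

In this assay this position, on a saturated chain carbon bound to a saturated ring carbon, turns out to respond to the group it carries: compound 1, compound 2 and compound 3 differ only within the scatter, whereas cyclopropylcarbamoyl in place of ethyl gives a 2.8-fold lower number from compound 3 to compound 4 (0.45 log units; beyond the scatter) and so breaks out of it. The other two comparisons run the same way and are of the same modest size, with a 2.9-fold lower number from compound 2 to compound 4 (0.46 log units; beyond the scatter) against the (piperidin-1-yl)methyl group and a 2.8-fold lower number from compound 1 to compound 4 (0.44 log units; beyond the scatter) against the 1,2-dihydroxyethyl group, which leaves compound 4 the most potent of the four in this set. No measurement at hand accounts for why this group separates from the other three.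

The carbonyl, the amide hydrogen and the cyclopropyl ring all enter together, and the compounds shown leave open which of them goes with the step. An unsubstituted carboxamide, a methyl amide, a cyclohexyl amide or a carboxylic acid on the same chain carbon would bear directly on that question.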